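The compounds below may be only part of what the source reports. "The series", "measured", "known", "first", "only" and "open" are said of these compounds alone.

Measured compounds in the series:

compound 1, `CCOC(=O)c1cnn(CC(O)CC)c1NC(=O)Nc1ccccc1F`, in a functional assay on cells (Neutrophil, Homo sapiens) for inhibition, with a stated time of 10 min (on this read-out higher numbers stand for weaker inhibition and lower numbers for stronger inhibition), gives 120 nM.
compound 2, `CCOC(=O)c1cnn(CC(C)O)c1NC(=O)Nc1cccc(F)c1`, in this assay gives > 10 nM, which is a limit of the assay and not a number.

Working notes. Compound 2 stands only as a limit in this assay; no number is available for it, so its place relative to compound 1 is not fixed by the data. (the limit of > 10 nM in this assay, at which 1 of the 2 values shown sits), the other value in the set is the number given for compound 1.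

Compound 3, `CCOC(=O)c1cnn(CC(O)CC)c1NC(=O)Nc1cccc(F)c1`, has not been measured in this assay. It differs from compound 2 by methyl in place of hydrogen on a saturated chain carbon, two bonds along the chain from an oxygen on a saturated carbon. Among the compounds with values here, no measured pair in the set carries this same change, so no step size for it is known here.

Expectation: with compound 2 known only as a limit, the step from compound 2 to compound 3 cannot be anchored; a change of this size on the chain is expected to stay within the scatter, and the estimated step is a step that the limit leaves unreadable from compound 2 to compound 3. For compound 3 the estimate in this assay is 80 nM, with a range from 20 nM to 400 nM.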

Compound 3, half-maximal inhibitory concentration: 0.19 nM
Estimate against measurement, compound 3: 420-fold (2.62 log units) above; measured number outside the range, below it.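

In this assay, going from 2-hydroxypropyl to 2-hydroxybutyl with the 3-fluorophenyl group held gives an at least 52-fold lower number from compound 2 to compound 3 (1.72 log units; beyond the scatter) and shows that a methyl in place of hydrogen on a saturated chain carbon, two bonds along the chain from an oxygen on a saturated carbon, can go with a large change in this series. The size of this step is only a bound, because compound 2 stands as a limit of the assay and not as a number: the limit of > 10 nM in this assay, at which 1 of the 3 values shown sits. With the 2-hydroxybutyl chain held, 3-fluorophenyl in place of 2-fluorophenyl on an amide-type nitrogen gives a 630-fold lower number from compound 1 to compound 3 (2.80 log units; beyond the scatter) and shows that this second place is just as sensitive, with a step that is a true number and rests on no limit.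

Still open, as far as these compounds go, is whether the trend on the chain continues to a longer chain such as 2-hydroxypentyl, or holds when an amine takes the place of the hydroxyl. Also open, from the compounds shown here alone, are how an unsubstituted phenyl on the amide-type nitrogen would read and whether the chain step and the fluorine step depend on each other.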